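The compounds below may be only part of what the source reports. "The series", "measured", "known", "first", "only" and "open" are said of these compounds alone.

Measured in a functional assay on MCF7 cells (Homo sapiens) for antiproliferative activity, read by MTT assay, with a stated time of 72 h; on this read-out higher numbers stand for weaker inhibition and lower numbers for stronger inhibition:
Compound 1 `COc1ccc(/C=C2\S/C(=N\c3ccc(C(C)(C)C)cc3)N(C)C2=O)cc1`: > 100000 nM (a limit)
Compound 2 `COc1ccc(/C=C2\S/C(=N\c3ccc(Br)cc3)N(C)C2=O)cc1`: > 100000 nM (a limit)
Compound 3 `C=CC/N=C1/NCC(=C)S1`: > 100000 nM (a limit)

None of these three readings is a number, and the picture is uniform: the limit of > 100000 nM in this assay, at which 3 of the 3 values shown sit. Compound 2 stands only at its limit of > 100000 nM. Its two companions give limits as well, so the series offers no numerical anchor.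

Compound 4 `COc1ccc(/C=C2\S/C(=N\c3ccc(OC)cc3)N(C)C2=O)cc1` has the core of compound 2 but carries methoxy in place of bromo on an aromatic carbon, para to a large group: methoxy in place of bromo on an aromatic carbon.

Among the compounds with values here, one measured step bears on this change, as it concerns the same place. It is a step that the two limits leave unreadable from compound 1 to compound 2, with bromo in place of tert-butyl on an aromatic carbon. Both of its ends are limits, so it has no readable size and gives no direction. Neither group brought a number into reach in this assay. Nothing measured therefore supports a step beyond the scatter, and another limit is the likeliest report. What is expected is a number no higher from compound 2 to compound 4 (the limit leaves the size open), with no direction foreseen. Compound 4 is estimated at 100000 nM, with an expected range from 30000 nM to 200000 nM.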

Compound 4, half-maximal inhibitory concentration: > 100000 nM
Compound 4 gave a limit, no number; the forecaster's own chance of this, stated with the estimate: 80%; the middle value sits exactly at the limit.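

In this assay compound 4 gives > 100000 nM, a limit and not a number. The steps from compound 1 and compound 2 to compound 4 therefore cannot be read, and the picture stays uniform: the limit of > 100000 nM in this assay, at which 4 of the 4 values shown sit. The compounds shown leave open whether tert-butyl, bromo and methoxy differ at all in their effect on this read-out.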